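The source may hold more compounds than are shown below. What is called first, only, known or untested is meant among the compounds shown, and "the series" means these compounds.

Measured in a functional assay on HepG2 cells (Homo sapiens) for cytotoxicity, read by MTT assay, with a stated time of 72 h (a higher number here means a weaker inhibitor, a lower number a stronger inhibitor), three compounds return only limits. Compound 1 (`Cc1c(C)c2c(c(C)c1OC(=O)CCC(=O)NC1CC(C)(C)N([O])C(C)(C)C1)CC[C@@](C)(CCC[C@H](C)CCC[C@H](C)CCCC(C)C)O2`) gives > 300000 nM as a limit. Compound 2 (`Cc1c(C)c2c(c(C)c1OC(=O)CCC(=O)O)CCC(C)(C(=O)NCC1CC(C)(C)N([O])C1(C)C)O2`) gives > 300000 nM as a limit too. Compound 3 (`Cc1c(C)c2c(c(C)c1OC(=O)CCC(=O)NC1CC(C)(C)N([O])C1(C)C)CC[C@@](C)(CCC[C@H](C)CCC[C@H](C)CCCC(C)C)O2`) likewise gives > 300000 nM as a limit, and no number places it. The set thus rests on the limit of > 300000 nM in this assay, at which 3 of the 3 values shown sit, alone. Compound 4 (`Cc1c(C)c2c(c(C)c1OC(=O)CCC(=O)NCC1CC(C)(C)N([O])C1(C)C)CC[C@@](C)(CCC[C@H](C)CCC[C@H](C)CCCC(C)C)O2`) departs from compound 3 on an amide-type nitrogen, where a group of 11 heavy atoms (9 carbon, 1 nitrogen, 1 oxygen; one five-membered non-aromatic ring with 1 hetero atom) in place of a group of 10 heavy atoms (8 carbon, 1 nitrogen, 1 oxygen; one five-membered non-aromatic ring with 1 hetero atom), on an amide-type nitrogen is the whole difference. Within the data shown here, the only measured step at that nitrogen is a step that the two limits leave unreadable from compound 1 to compound 3 and it offers no size to carry over. The expected size of a number no higher from compound 3 to compound 4 (the limit leaves the size open) is nothing beyond the scatter, in neither direction. In this assay compound 4 is estimated at 300000 nM within a range from 150000 nM to 450000 nM and is expected to return a limit again.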

Compound 4, half-maximal inhibitory concentration: > 300000 nM
Compound 4 was reported as a limit; the forecaster's own chance of this, stated with the estimate: 90%; the middle value lies on the limit itself.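

Among these compounds, compound 4 also returns only a limit, so no step from compound 1 or compound 3 to compound 4 can be read: the limit of > 300000 nM in this assay, at which 4 of the 4 values shown sit. The compounds shown leave open whether the group on the amide-type nitrogen affects the result in this assay at all.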